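Adding a chloro to compound 2

The source may hold more compounds than are shown below. What is called first, only, known or untested is meant among the compounds shown, and "the series" means these compounds.

In a physicochemical assay for solubility (a lower number here means a less soluble compound, a higher number a more soluble compound), compound 1 `O=C(Nc1ccccc1Cl)c1cc(Cl)ccc1O` gives 5 ug/mL. Compound 2 `O=C(Nc1ccc(C(F)(F)F)cc1)c1cc(Cl)ccc1O` gives < 1 ug/mL, which is a limit of the assay and not a number. So compound 1 has a measured value, while compound 2 has only this limit.

Compound 3 `O=C(Nc1ccc(C(F)(F)F)cc1Cl)c1cc(Cl)ccc1O` differs from compound 2 in one place: chloro in place of hydrogen on an aromatic carbon. This puts chloro in place of hydrogen on an aromatic carbon, ortho to a large group and meta to a trifluoromethyl group.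

Among the measured compounds shown here, no measured pair shows this change alone, so any expectation is rough. A small downward step in this assay, or none beyond the scatter, is expected because compound 2 sits at the limit of < 1 ug/mL. The estimated step is a step that the limit leaves unreadable from compound 2 to compound 3. For compound 3 the estimate is 0.6 ug/mL, with an expected range from 0.2 ug/mL to 2 ug/mL.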

Compound 3, solubility: < 1 ug/mL
Compound 3: a limit, no number; the forecaster's own chance of this, stated with the estimate: 75%; the middle value is on the limit's open side.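

Among the compounds shown here, the first one-place change with a readable size adds a trifluoromethyl group: in this assay it gives an at least 5.0-fold lower number from compound 1 to compound 3 (0.69 log units; beyond the scatter). Compound 3 gives < 1 ug/mL, which is a limit of the assay and not a number. The added chloro, ortho to a large group and meta to a trifluoromethyl group, therefore has no step that can be read, because compound 2 and compound 3 both rest on the same limit: the limit of < 1 ug/mL in this assay, at which 2 of the 3 values shown sit.

As far as these compounds go, whether this chloro raises, lowers or leaves unchanged the true solubility remains open, since both true values lie out of the assay's reach. Also open, from the compounds shown here alone, is whether an amine or a carboxylic acid in place of the trifluoromethyl group would bring the read-out back to a measurable number.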